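Thiazole series: ester to acid at the carbonyl-bearing position

The source may hold more compounds than are shown below. What is called first, only, known or untested is meant among the compounds shown, and "the series" means these compounds.

Measured so far:
compound 1 `CCOC(=O)c1sc(-c2cccc(NC(=O)c3ccccc3F)c2)nc1Nc1ccc(N2CCN(C)CC2)cc1`, 2000 nM
compound 2 `CCOC(=O)c1sc(-c2cccc(NC(=O)c3ccc(Cl)cc3)c2)nc1Nc1ccc(N2CCN(C)CC2)cc1`, "not determined" (no result reported)
compound 3 `CCOC(=O)c1sc(-c2cccc(NC(=O)c3ccc(F)c(Cl)c3)c2)nc1Nc1ccc(N2CCN(C)CC2)cc1`, 29200 nM

In a functional assay on Ramos cells (Homo sapiens) for antiproliferative activity, read by CCK-8 assay, with a stated time of 72 h (a higher number here means a weaker inhibitor, a lower number a stronger inhibitor), compound 1 gives 2000 nM; for compound 2 the entry is "not determined" (no result reported). Compound 3 gives 29200 nM in this assay, the highest of the two numbers available; the nearest is compound 1, with a 15-fold higher number from compound 1 to compound 3 (1.16 log units; beyond the scatter).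

Compound 4 `CN1CCN(c2ccc(Nc3nc(-c4cccc(NC(=O)c5ccc(F)c(Cl)c5)c4)sc3C(=O)O)cc2)CC1` differs from compound 3 by hydrogen in place of ethyl on an oxygen next to a carbonyl group. No measured step touches the ester; the single step shown, a 15-fold higher number from compound 1 to compound 3 (1.16 log units; beyond the scatter), changes the amide aryl group and says nothing about this position. No step beyond the scatter is therefore expected in this assay, a 1.2-fold higher number from compound 3 to compound 4 (0.08 log units; within the scatter). For compound 4 the estimate is 35000 nM, with range 8000 nM to 150000 nM.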

Compound 4, half-maximal inhibitory concentration: 5600 nM
Compound 4: middle estimate off by 6.3-fold (0.80 log units), on the high side; measured number outside the range, below it.
By their numbers in this assay, from the lowest: compound 1; then compound 4; then compound 3.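

Ethoxycarbonyl to carboxy is the first change at this position, and in this assay it gives a 5.2-fold lower number from compound 3 to compound 4 (0.72 log units; beyond the scatter). The position therefore responds to substitution, and with the 3-chloro-4-fluorophenyl amide held constant, the ethyl group is not needed to retain activity in this pair. Nothing available explains the step.

As far as these compounds go, whether the same step holds with the 2-fluorophenyl amide of compound 1 remains open, since a single pair sets no trend. From the compounds shown here alone, how a primary amide or a methyl ester at this carbonyl would read also remains open.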